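From Cyclobutyl to Isopropyl Without a Starting Number

This account rests on a few compounds, and the source may have more. Where it says the series, first, only, none or still open, it means among the compounds named here.

For the measured compounds named here, the only number in this small set belongs to compound 1 `CC(C)N1CCC2(CC1)CC2C(=O)N1CCN(C2CCCCC2)CC1`, which gives 0.74 in a physicochemical assay for lipophilicity, read by HPLC, using the shake flask method, measured as octanol-water partition; on this read-out higher numbers stand for higher lipophilicity and lower numbers for lower lipophilicity. For compound 2 `O=C(C1CC2(CCN(C3CCOCC3)CC2)C1)N1CCN(C2CCC2)CC1`, the entry in this assay is "not determined" (no result reported), so it offers no value to build on. The next structure is compound 3 `CC(C)N1CCN(C(=O)C2CC3(CCN(C4CCOCC4)CC3)C2)CC1`. The change isopropyl in place of cyclobutyl on an amine nitrogen in a ring is isopropyl in place of cyclobutyl on an amine nitrogen in a ring. Going by the values given here, no measured pair shows what this swap does, but no shift beyond the usual scatter is expected in this assay. Among the compounds with values here, with compound 1 at 0.74 as the sole guide, the estimate remains loose. For compound 3, the expected value is 0.2, within an estimated range of -0.4 to 0.8.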

Compound 3, distribution coefficient: -0.74
Estimate against measurement, compound 3: 0.94 log units above; measured number below the stated range.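

For the compounds shown here, compound 2 has no reported value to set against compound 3, so no step between them can be read. What isopropyl in place of cyclobutyl does in this assay stays open, and no evidence at hand accounts for the value of compound 3.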